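Working notes: from compound 3 to compound 4

The compounds below may be only part of what the source reports. "The series", "measured", "known", "first", "only" and "open" are said of these compounds alone.

Values in an ADME assay on MT4 cells (Homo sapiens) for cytotoxicity, read by MTT assay, with a stated time of 96 h (on this read-out higher numbers stand for lower toxicity in this test and lower numbers for higher toxicity in this test), so far
- compound 1 `C/C(=N\NC(N)=S)c1ccc2[nH]c(-c3ccc(Cl)cc3)nc2c1` gives 2000 nM
- compound 2 `COc1ccc(-c2nc3cc(/C(C)=N/NC(N)=O)ccc3n2C2CCCCC2)c(OC)c1` gives 23000 nM
- compound 3 `C/C(=N\NC(N)=S)c1ccc2c(c1)nc(-c1ccc(Cl)cc1)n2C1CCCCC1` gives 17000 nM

Compound 3 sits within the scatter of compound 2. For the measured compounds named here, the one measured step, an 8.5-fold higher number from compound 1 to compound 3 (0.93 log units; beyond the scatter), lies beyond the scatter, but it is cyclohexyl in place of hydrogen on an aromatic nitrogen, so it does not bear directly on the next change. Compound 4 `COc1ccc(-c2nc3cc(/C(C)=N/NC(N)=S)ccc3n2C2CCCCC2)c(OC)c1` differs from compound 3 by 2,4-dimethoxyphenyl in place of 4-chlorophenyl on an aromatic carbon, between two ring nitrogen atoms. Going by the values given here, no step at this carbon has been measured. Compound 2 already carries 2,4-dimethoxyphenyl and gives 23000 nM in this assay, so no step beyond the scatter is expected. The estimate means a 1.2-fold higher number from compound 3 to compound 4 (0.07 log units; within the scatter) as the expected change. Compound 4 is expected at 20000 nM (estimated range 8000 nM to 50000 nM).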

Compound 4, half-maximal cytotoxic concentration: 17000 nM
Beside the measured number, compound 4's estimate is 1.2-fold (0.07 log units) above it; the range from low to high includes it.
By their numbers in this assay, from the lowest: compound 1; then compounds 3, 4 and 2 (each within the scatter of the next).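

In this assay the aromatic carbon between two ring nitrogen atoms has its first measured step, no change at the digits printed from compound 3 to compound 4 (within the scatter), for 2,4-dimethoxyphenyl in place of 4-chlorophenyl with cyclohexyl in the series. The sulfur-bearing group in place of the oxygen-bearing group on an amine nitrogen gives a 1.4-fold lower number from compound 2 to compound 4 (0.13 log units; within the scatter), so neither change moves the number beyond the scatter. Nothing available accounts for either result. Still open, going by these compounds, is how an amine, a carboxylic acid or a longer chain at this carbon would read, and whether either step holds without the cyclohexyl group.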